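A few compounds are considered here, and "the series" means these few. Any claim that something is new, unique, unknown or untested is made for them only; others in the source may bear on it.

Three compounds share one core and differ only in the group on a carbon with a double bond to nitrogen. In a functional assay on EKVX cells (Homo sapiens) for inhibition, read by sulforhodamine B assay, with a stated time of 48 h (a lower number here means a stronger inhibitor of growth, a higher number a weaker inhibitor of growth), compound 1 (`O=C(Cc1csc2nc(-c3ccc(Br)cc3)cn12)N/N=C/c1ccccc1O`) gives 19100 nM, and compound 2 (`O=C(Cc1csc2nc(-c3ccc(Br)cc3)cn12)N/N=C/c1ccc(O)cc1`) gives 66100 nM. Compound 3 (`COc1cccc(OC)c1/C=N/NC(=O)Cc1csc2nc(-c3ccc(Br)cc3)cn12`) gives 57500 nM, level with compound 2 within the scatter, as a 1.1-fold lower number from compound 2 to compound 3 (0.06 log units; within the scatter) shows. Compound 1 is the strongest growth inhibitor of the three, and a 3.0-fold higher number from compound 1 to compound 3 (0.48 log units; beyond the scatter) sets compound 3 apart from it, a modest step much like a 3.5-fold higher number from compound 1 to compound 2 (0.54 log units; beyond the scatter).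

Compound 4 (`O=C(Cc1csc2nc(-c3ccc(Br)cc3)cn12)N/N=C/c1ccc(Cl)cc1Cl`) follows from compound 3 by one change, (2,4-dichlorophenyl in place of 2,6-dimethoxyphenyl on a carbon with a double bond to nitrogen), with 2,4-dichlorophenyl in place of 2,6-dimethoxyphenyl on a carbon with a double bond to nitrogen. Going by the values given here, all three measured steps change this same group, but no measured compound carries chlorine, so the data do not show this change directly. Compound 4 lacks the 2-hydroxyphenyl of compound 1, as do compound 2 and compound 3, so no step beyond the scatter is expected in this assay. The expected step is a 1.4-fold lower number from compound 3 to compound 4 (0.16 log units; within the scatter), a small one. For compound 4 the estimated value is 40000 nM, with an expected range from 14000 nM to 100000 nM.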

Compound 4, concentration for total growth inhibition: > 100000 nM
Compound 4 was reported as a limit (the forecaster's own chance of this, stated with the estimate: 15%); middle value at least 2.5-fold (0.39 log units) from the limit.
By their numbers in this assay, from the lowest: compound 1; then compounds 3 and 2 (each within the scatter of the next). At a limit, above all of these: compound 4.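

Compound 4 is reported in this assay only as a limit: the limit of > 100000 nM in this assay, at which 1 of the 4 values shown sits. This is the only compound shown with chlorine on the phenyl group at this position, and that change brings no number lower than those of the earlier compounds. Compound 1 keeps a clear lead over the new compound, with an at least 5.2-fold higher number from compound 1 to compound 4 (0.71 log units; beyond the scatter), so the gap seen for the 2-hydroxyphenyl group now extends to 2,4-dichlorophenyl, while the comparisons with the other two compounds, an at least 1.7-fold higher number from compound 3 to compound 4 (0.24 log units; that floor lies within the scatter) and an at least 1.5-fold higher number from compound 2 to compound 4 (0.17 log units; that floor lies within the scatter), give floors that do not by themselves set compound 4 apart from compound 3 or compound 2.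

How far compound 4 really lies from compound 3 and compound 2 stays open, as the limit gives only these floors, and the compounds shown do not separate the effect of the two chlorines from one another, since no phenyl group with a single chlorine appears among them. Also open, going by these compounds, is whether the lead of compound 1 is specific to its hydroxyl, as no aminophenyl group or phenyl group carrying a carboxylic acid stands at this position here.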